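The compounds below may be only part of what the source reports. "The series", "measured", "known", "first", "only" and "open" are said of these compounds alone.

Of the compounds shown here, three sharing one core have been measured in a functional assay on KBVIN cells (Homo sapiens) for antiproliferative activity, read by sulforhodamine B assay, with a stated time of 48 h; a higher number here means a weaker inhibitor of growth, a lower number a stronger inhibitor of growth. Compound 1 `CCCNc1nc(Nc2ccc(OC)cc2)nc2ccccc12` gives 5090 nM, and compound 2 `N#Cc1ccc(Nc2nc(NCCCO)c3ccccc3n2)cc1` gives 4310 nM. Compound 3 `OCCCNc1nc(Nc2ccc(F)cc2)nc2ccccc12` gives 24200 nM, the highest number of the three and beyond the scatter from both others.

Compound 4 `CCCNc1nc(Nc2ccc(F)cc2)nc2ccccc12` departs from compound 3 by one change: hydrogen in place of hydroxy on a saturated chain carbon, three bonds along the chain from a nitrogen on an aromatic ring. In words, this is hydrogen in place of hydroxy on a saturated chain carbon, three bonds along the chain from a nitrogen on an aromatic ring, so 3-hydroxypropyl becomes propyl.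

Within the data shown here, no measured step makes this change. Among the measured compounds shown here, the only step available, a 5.6-fold higher number from compound 2 to compound 3 (0.75 log units; beyond the scatter), is fluoro in place of cyano on an aromatic carbon, so it shows how far one change can move this assay in this small set but not in which direction this one will. The closest guide is compound 1, which already carries propyl and gives 5090 nM, although it also has methoxy where compound 3 has fluoro. A modest move toward a lower number is therefore expected, of a size similar to the measured step, though this rests on thin evidence.

The expected step is a 2.7-fold lower number from compound 3 to compound 4 (0.43 log units; beyond the scatter). Compound 4 is estimated at 9000 nM, with an expected range of 3000 nM to 26000 nM.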

Compound 4, concentration for 50% growth inhibition: 2500 nM
Estimate against measurement, compound 4: 3.6-fold (0.56 log units) above; the measured number lies below the stated range.
By their numbers in this assay, from the lowest: compounds 4, 2 and 1 (each within the scatter of the next, the first and the last beyond it); then compound 3.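

In this assay, among these compounds, the first step at this chain position, a 9.7-fold lower number from compound 3 to compound 4 (0.99 log units; beyond the scatter), shows that with fluoro held fixed, hydrogen in place of hydroxy on the saturated chain carbon, three bonds along the chain from a nitrogen on an aromatic ring, gives a clearly lower number. Among the compounds shown here, with propyl held fixed, a 2.0-fold lower number from compound 1 to compound 4 (0.31 log units; beyond the scatter) is a smaller step on the aromatic carbon, printed as just beyond the scatter, and it is the first comparison of fluoro and methoxy in this set. Nothing at hand accounts for the size or direction of the change from 3-hydroxypropyl to propyl.

This hydroxy-to-hydrogen change is seen only in the fluoro series, so the compounds shown leave open whether it would lower the number to a similar extent with nitrile or methoxy on the aromatic carbon. They also leave open how the number would respond to a longer chain such as butyl, or to an amine or a carboxylic acid at the end of the propyl chain in place of the hydroxy of compound 3.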